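Swapping a Butyl for a Trifluoromethyl on the Core

The compounds below may be only part of what the source reports. "The series", "measured", "known", "first", "only" and "open" are said of these compounds alone.

Measured compounds:
- Compound 1, `CCCc1ccc(S(=O)(=O)NC(=O)OCCCC(F)(F)F)c(-c2ccc(Cn3c(C(C)(C)C)nc4ccccc43)cc2)c1`: 4.5 nM
- Compound 2, `CCCCOC(=O)NS(=O)(=O)c1ccc(CCC)cc1-c1ccc(Cn2c(CCCC)nc3ccccc32)cc1`: 9.2 nM
- Compound 3, `CCCCOC(=O)NS(=O)(=O)c1ccc(CCC)cc1-c1ccc(Cn2c(C3CCC3)nc3ccccc32)cc1`: 12 nM

In an assay on membranes from HEK293 cells for displacement of a labelled ligand from Type-2 angiotensin II receptor (Homo sapiens), read by radioligand binding (on this read-out higher numbers stand for weaker inhibition and lower numbers for stronger inhibition), compound 2 gives 9.2 nM, the second highest of the three numbers. Its nearest neighbour is compound 3, and the step of a 1.3-fold higher number from compound 2 to compound 3 (0.12 log units; within the scatter) lies within the scatter. Compound 1 gives 4.5 nM, a lower number, but it differs from compound 2 in more than one place, so that pair says nothing about a single change.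

Compound 4, `CCCCOC(=O)NS(=O)(=O)c1ccc(CCC)cc1-c1ccc(Cn2c(C(F)(F)F)nc3ccccc32)cc1`, has not yet been measured. It differs from compound 2 in one place: trifluoromethyl in place of butyl on an aromatic carbon. Within the data shown here, the only single step that bears on this position is the one from compound 2 to compound 3, where a ring of similar size replaced the butyl and the number hardly moved. Among the measured compounds shown here, a trifluoromethyl is a different kind of replacement, carrying three fluorine atoms instead of a carbon chain, and no measured step shows such a swap. The expectation therefore stays close to compound 2, with a modest upward lean and a wide range.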

Compound 4, inhibition constant: 13 nM
For compound 4 the middle estimate is 1.5-fold (0.19 log units) above the measured one; the range from low to high includes it.
By their numbers in this assay, from the lowest: compound 1; then compounds 2, 3 and 4 (each within the scatter of the next).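

In this assay, this carbon of the five-membered aromatic ring, between two ring nitrogen atoms, now shows little response to a second, very different replacement: trifluoromethyl puts fluorine where butyl had only carbon, with the same count of heavy atoms, and the result is small (a 1.4-fold higher number from compound 2 to compound 4 (0.15 log units; within the scatter)). The comparison with the ring-bearing analogue is just as flat (a 1.1-fold higher number from compound 3 to compound 4 (0.03 log units; within the scatter)), so a straight chain, a small ring and a fluorinated carbon all fall within the scatter of one another at this position. No measurement here accounts for this lack of separation.

On these data alone, whether an amine, a carboxylic acid or a longer chain would stay equally close to compound 2 remains open. As far as these compounds go, it is also open whether trifluoromethyl would behave the same way on the core of compound 1.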